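This account rests on a few compounds, and the source may have more. Where it says the series, first, only, none or still open, it means among the compounds named here.

Compound 1 `O=C(Nc1cccc(-c2oc3cc(-c4ccc(F)cc4)ccc3c(=O)c2O)c1)c1ccccc1F`: 7570 nM
Compound 2 `Cc1cccc(C(=O)Nc2cccc(-c3oc4cc(-c5ccc(F)cc5)ccc4c(=O)c3O)c2)c1`: 7850 nM

In a functional assay on MCF7 cells (Homo sapiens) for antiproliferative activity, read by CCK-8 assay, with a stated time of 72 h (a higher number here means a weaker inhibitor, a lower number a stronger inhibitor), compound 1 gives 7570 nM, the lowest of the two numbers shown, while compound 2 gives 7850 nM. Among the measured compounds shown here, the only measured step is a 1.0-fold higher number from compound 1 to compound 2 (0.02 log units; within the scatter), a change of the group on the carbonyl carbon that left the number essentially where it was. Compound 3 `O=C(Nc1cccc(-c2oc3cc(-c4ccc(F)cc4)ccc3c(=O)c2O)c1)c1cccc(F)c1` differs from compound 1 by 3-fluorophenyl in place of 2-fluorophenyl on a carbonyl carbon. For the measured compounds named here, since the one comparable change at this carbonyl carbon stayed within the scatter, no step beyond the scatter is expected here either, and compound 3 is estimated at 7500 nM in this assay, between 3500 nM and 16000 nM, meaning a 1.0-fold lower number from compound 1 to compound 3 (0.00 log units; within the scatter).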

Compound 3, half-maximal inhibitory concentration: 5770 nM
The estimate for compound 3 lay 1.3-fold (0.11 log units) above the measured number, and the stated range covers the measured number.
By their numbers in this assay, from the lowest: compounds 3, 1 and 2 (each within the scatter of the next).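

Moving the fluorine, with 3-fluorophenyl in place of 2-fluorophenyl on the carbonyl carbon, gives a 1.3-fold lower number from compound 1 to compound 3 (0.12 log units; within the scatter) and so stays inside the usual scatter. Fluoro in place of methyl on an aromatic carbon gives a 1.4-fold lower number from compound 2 to compound 3 (0.13 log units; within the scatter) and also stays inside it, so three forms of this ring now show no step beyond the scatter. No outside measurement is available to explain these small differences. Going by these compounds, whether an amine or a carboxylic acid on this ring, or cyclohexyl in place of the phenyl, would shift the number remains open.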